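The source may hold more compounds than are shown below. What is called first, only, known or untested is meant among the compounds shown, and "the series" means these compounds.

Compound 1 `O=C(O)c1ccc2c(c1)no[n+]2[O-]`: "not determined" (no result reported)
Compound 2 `O=C(CCCOC(=O)c1ccc2c(c1)no[n+]2[O-])NO`: 13000 nM
Compound 3 `O=C(CCCCOC(=O)c1ccc2c(c1)no[n+]2[O-])NO`: 19900 nM

In a functional assay on U-937 cells (Homo sapiens) for inhibition, read by MTT assay, with a stated time of 48 h (a lower number here means a stronger inhibitor, a higher number a weaker inhibitor), compound 3 gives 19900 nM and compound 2 gives 13000 nM, two values within the usual scatter of each other. Compound 1, the shared core as a free acid, has no number to compare.

Compound 4 `O=C(CCCCCOC(=O)c1ccc2c(c1)no[n+]2[O-])NO` lengthens the chain of compound 3: (hydroxycarbamoyl)methyl in place of hydroxycarbamoyl on a saturated chain carbon, four bonds along the chain from an oxygen next to a carbonyl group. Among the compounds with values here, the only measured step of this kind is a 1.5-fold higher number from compound 2 to compound 3 (0.18 log units; within the scatter), the same change made three bonds along the chain instead of four. That step stays within the scatter, so no shift beyond the scatter is expected, and the expected step is a 1.1-fold lower number from compound 3 to compound 4 (0.04 log units; within the scatter). For compound 4 the estimated value is 18000 nM, with an expected range of 8000 nM to 40000 nM.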

Compound 4, half-maximal inhibitory concentration: 33400 nM
Compound 4: middle estimate off by 1.9-fold (0.27 log units), on the low side, and the stated range covers the measured number.
By their numbers in this assay, from the lowest: compounds 2, 3 and 4 (each within the scatter of the next, the first and the last beyond it).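

In this assay, moving to (hydroxycarbamoyl)methyl in place of hydroxycarbamoyl four bonds along the chain again stays within the scatter (a 1.7-fold higher number from compound 3 to compound 4 (0.22 log units; within the scatter)). The larger change, 2-(hydroxycarbamoyl)ethyl in place of hydroxycarbamoyl, gives the first step beyond the scatter, though a modest one (a 2.6-fold higher number from compound 2 to compound 4 (0.41 log units; beyond the scatter)), so a longer chain here costs some strength only across the full span of these compounds. No measured evidence explains this shift.

A still longer chain remains untested among the compounds shown. So does a carboxylic acid or an amine at the chain end in place of hydroxycarbamoyl.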